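Fluorinated phenylurea series on rice

This account rests on a few compounds, and the source may have more. Where it says the series, first, only, none or still open, it means among the compounds named here.

Three compounds carry numbers in an ADME assay on the whole organism with Oryza sativa as the target, tested at 1 uM; on this read-out lower numbers stand for a stronger effect and higher numbers for a weaker effect at the one concentration tested. Compound 1 `C[C@@H](NC(=O)Nc1ccccc1F)c1ccccc1` gives 95%. Compound 2 `C[C@H](NC(=O)Nc1ccc(F)cc1)c1ccccc1` gives 97% in this assay, and the difference between the cores of compound 1 and compound 2 is not broken down here. Compound 3 `C[C@H](NC(=O)Nc1ccc(F)cc1F)c1ccccc1` gives 100%. The change from compound 2 to compound 3 is fluoro in place of hydrogen on an aromatic carbon, and it made a number 3 percentage points higher from compound 2 to compound 3 (within the scatter). The same change, (fluoro in place of hydrogen on an aromatic carbon), leads from compound 1 to compound 4 `C[C@@H](NC(=O)Nc1c(F)cccc1F)c1ccccc1`, which has not been measured in this assay. This change occurs twice among the compounds shown. The step of a number 3 percentage points higher from compound 1 to compound 4 (within the scatter) is expected to match the earlier one, resting on a number 3 percentage points higher from compound 2 to compound 3 (within the scatter) alone. For compound 4 the estimate in this assay is 98%, with an expected range of 90% to 100%.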

Compound 4, a percentage reported as activity, at one concentration (the size of the read-out at that concentration, not a potency): 100%
Estimate against measurement, compound 4: 2 percentage points below; the range from low to high includes it.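

In this assay the new step is a number 5 percentage points higher from compound 1 to compound 4 (within the scatter), for fluoro in place of hydrogen on an aromatic carbon. Carried from one core to the other, the change gives two steps that cannot be told apart: the same change on two cores in this assay, a number 3 percentage points higher (within the scatter) from compound 2 to compound 3 and a number 5 percentage points higher (within the scatter) from compound 1 to compound 4, 2 percentage points apart, within the scatter of two such steps. For the compounds shown here, both steps lie within the scatter, so this shows only that the change left the read-out unresolved on these two cores; it does not show a real effect of the fluoro group, nor that the agreement extends to any other core.

Open, going by these compounds, is whether any other group on the aromatic ring, such as chloro, methoxy, an amine or a carboxylic acid, would give a step beyond the scatter in this assay. Also open, on these data alone, is whether a longer chain in place of the methyl group would do so.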